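Compound 2 to compound 4: benzyl to 4-methylbenzyl

A few compounds are considered here, and "the series" means these few. Any claim that something is new, unique, unknown or untested is made for them only; others in the source may bear on it.

Measured in a functional assay on RS4-11 cells (Homo sapiens) for inhibition, read by CCK-8 assay, with a stated time of 48 h, tested at 20 uM; a lower number here means less inhibition of growth, a higher number more inhibition of growth at the concentration tested:
compound 1 `COc1ccc(Cc2nnc(NC(=O)/C(C#N)=C/c3ccccc3OS(=O)(=O)c3ccc(OC)cc3)s2)cc1` gives 78%
compound 2 `COc1ccc(S(=O)(=O)Oc2ccccc2/C=C(\C#N)C(=O)Nc2nnc(Cc3ccccc3)s2)cc1` gives 78%
compound 3 `N#C/C(=C\c1ccccc1OS(=O)(=O)c1ccccc1[N+](=O)[O-])C(=O)Nc1nnc(Cc2ccccc2)s1` gives 71%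

Compound 2 stands within the scatter of both measured neighbours. Its steps show no change at the digits printed from compound 1 to compound 2 (within the scatter) and a number 7 percentage points lower from compound 2 to compound 3 (within the scatter) on the sulfonyl side.

Compound 4 `COc1ccc(S(=O)(=O)Oc2ccccc2/C=C(\C#N)C(=O)Nc2nnc(Cc3ccc(C)cc3)s2)cc1` has one change from compound 2: methyl in place of hydrogen on an aromatic carbon so that benzyl becomes 4-methylbenzyl. Compound 1 carries a substituent on that same benzyl group, and the step measured there is no change at the digits printed from compound 1 to compound 2 (within the scatter) as the closest guide. The sulfonyl step lies elsewhere and bears less. No step beyond the scatter is therefore expected in this assay here. The estimated step is a number 2 percentage points lower from compound 2 to compound 4 (within the scatter) in this series. Compound 4 is estimated at 76% with an expected range of 64% to 86% as its limits.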

Compound 4, percent growth inhibition at one concentration: 79%
Beside the measured number, compound 4's estimate is 3 percentage points below it; the measured number falls inside the stated range.
By their numbers in this assay, from the lowest: compounds 3, 1, 2 and 4 (each within the scatter of the next).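

In this assay, methyl in place of hydrogen on the benzyl ring gives a number 1 percentage points higher from compound 2 to compound 4 (within the scatter) and methyl in place of methoxy gives a number 1 percentage points higher from compound 1 to compound 4 (within the scatter) on the same aromatic carbon. Hydrogen, methyl and methoxy at this carbon therefore cannot be told apart at the single concentration tested, so this small alkyl group joins methoxy as tolerated here. No evidence on a cause accompanies these numbers.

On these data alone, whether an amine, a carboxylic acid or a longer chain such as butyl at this carbon would move the read-out beyond the scatter stays open. As far as these compounds go, whether these three compounds separate at lower concentrations also stays open.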